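The source may hold more compounds than are shown below. What is called first, only, known or untested is meant among the compounds shown, and "the series" means these compounds.

In a functional assay on aorta with Voltage-dependent L-type calcium channel subunit alpha-1C (Oryctolagus cuniculus) as the target (a higher number here means a weaker inhibitor, a lower number a stronger inhibitor), compound 2 `CC1=NC(C)=C(C(=O)OCN2C(=O)c3ccccc3S2(=O)=O)C(c2ccccc2[N+](=O)[O-])/C1=C(\O)OCC1CCCCO1` gives 25.1 nM. Among the measured compounds shown here, only one other number exists so far: compound 1 `CC1=NC(C)=C(C(=O)OCN2C(=O)c3ccccc3S2(=O)=O)C(c2cccc([N+](=O)[O-])c2)/C1=C(\O)OCC1CCCCO1` gives 13.3 nM in this assay, and the step of a 1.9-fold higher number from compound 1 to compound 2 (0.28 log units; within the scatter) shows that the two compounds cannot be told apart, so compound 2 stands level with compound 1 rather than apart from it. Compound 3 `CC1=NC(C)=C(C(=O)OCN2C(=O)c3ccccc3S2(=O)=O)C(c2ccccc2C(F)(F)F)/C1=C(\O)OCC1CCCCO1` differs from compound 2 in a single spot: trifluoromethyl in place of nitro on an aromatic carbon. For the measured compounds named here, no measured step bears on this exchange; the only step known changes where a nitro group sits on the ring, not what the group is, and that step stayed within the scatter. Without a direct precedent, the expectation for compound 3 is a step of a 1.0-fold lower number from compound 2 to compound 3 (0.00 log units; within the scatter), which means no change beyond the scatter in this assay. Compound 3 is therefore estimated at 25 nM, with a range from 8 nM to 80 nM that allows for the lack of any guiding comparison.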

Compound 3, half-maximal inhibitory concentration: 3.6 nM
Compound 3: middle estimate off by 6.9-fold (0.84 log units), on the high side; the whole stated range lies above it.
By their numbers in this assay, from the lowest: compound 3; then compounds 1 and 2 (each within the scatter of the next).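

Changing what the group is matters more here than moving it. In this assay, trifluoromethyl in place of nitro on this aromatic carbon, ortho to a large group, gives a 7.0-fold lower number from compound 2 to compound 3 (0.84 log units; beyond the scatter), whereas moving the nitro group gave only a 1.9-fold higher number from compound 1 to compound 2 (0.28 log units; within the scatter). The 2-(trifluoromethyl)phenyl group also compares well with the 3-nitrophenyl group, with a 3.7-fold lower number from compound 1 to compound 3 (0.57 log units; beyond the scatter), so compound 3 is the strongest inhibitor of the three in this assay, and the change of group stands out clearly from the scatter. Nothing shown here explains why this exchange has such an effect.

The compounds shown leave open whether trifluoromethyl would keep this edge if placed where the nitro group sits in compound 1, and how a chlorine atom, a methoxy group or a nitrile would compare on this same aromatic carbon. They also leave open whether the step would hold on a changed core, for example with a simple ethyl ester in place of the ester chain that all three compounds share.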